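This account rests on a few compounds, and the source may have more. Where it says the series, first, only, none or still open, it means among the compounds named here.

Notes on the series. Within the data shown here, compound 1 `N=C(NCCCc1c[nH]cn1)NCCSC(c1ccccc1)c1ccccn1` and compound 2 `N=C(NCCCc1c[nH]cn1)NCCC(c1ccccc1)c1ccccn1` are the two measured members. In a functional assay on cardiac atrium for agonist activity at histamine H2 receptor (Cavia porcellus) (on this read-out lower numbers stand for lower potency and higher numbers for higher potency (the scale is a negative logarithm)), compound 1 gives 6.6, and compound 2 gives 7.39. Compound 2 thus holds the higher of the two numbers recorded so far; its nearest neighbour is compound 1, whose value lies lower by a gap that is beyond the usual scatter. Among the measured compounds shown here, no single-point step between measured compounds has been characterised, so the size of the next change can only be expected, not read from precedent.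

Compound 3 `N=C(NCCCc1c[nH]cn1)NCCC(c1ccc(F)cc1)c1ccccn1` follows from compound 2 by one change: fluoro in place of hydrogen on an aromatic carbon, or phenyl to 4-fluorophenyl when read one bond further out. For the measured compounds named here, nothing among the measured compounds shows how this assay responds to a fluoro at that position. In this assay the expected step is small, a number 0.09 log units lower from compound 2 to compound 3 (within the scatter), not beyond the scatter in either direction. Compound 3 is therefore estimated at 7.3 in this assay, with a range from 6.8 to 7.8.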

Compound 3, negative logarithm of the half-maximal effective concentration: 8.01
Compound 3: the middle estimate sits 0.71 log units below what was measured, and the stated range ends below it.
By their numbers in this assay, from the lowest: compound 1; then compound 2; then compound 3.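

Substitution on this six-membered aromatic ring, para to a large group, registers in this assay: fluoro in place of hydrogen on an aromatic carbon gives a number 0.62 log units higher from compound 2 to compound 3 (beyond the scatter). Among these compounds, this is the first single-point step, and it shows that the phenyl of compound 2 is not a silent part of the structure, since replacing a hydrogen atom with one fluorine, with no ring, no hydrogen-bond donor or acceptor and no net charge added, is enough to move the number beyond the scatter. The data on hand give no measured basis for explaining the rise.

The compounds shown leave open whether the gain is specific to fluoro or also appears with a larger group at the same place, such as chloro, methyl, methoxy or trifluoromethyl, and a single step cannot show a trend across substituents. On these data alone, it also remains open whether phenyl to 4-fluorophenyl changes the number by a similar amount on the core of compound 1, or whether the step holds only on the core of compound 2.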